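The source may hold more compounds than are shown below. What is called first, only, known or untested is meant among the compounds shown, and "the series" means these compounds.

Among the compounds with values here, in a functional assay on Huh-7 cells (Homo sapiens) for inhibition, read by MTT assay, with a stated time of 48 h (a higher number here means a weaker inhibitor, a lower number a stronger inhibitor), compound 1 `COc1ccc2c(=O)c(/C=C/C(=O)Nc3ccccc3)coc2c1` gives 9050 nM, and compound 2 `COc1ccc2c(=O)c(/C=C/C(=O)Nc3cc(C)ccc3C)coc2c1` gives 11100 nM; compound 2 stands within the scatter of compound 1, the only other number, the step being a 1.2-fold higher number from compound 1 to compound 2 (0.09 log units; within the scatter). Compound 3 `COc1cccc(NC(=O)/C=C/c2coc3cc(OC)ccc3c2=O)c1` differs from compound 2 by 3-methoxyphenyl in place of 2,5-dimethylphenyl on an amide-type nitrogen. Within the data shown here, the one measured step that bears on this, the earlier exchange at the same amide-type nitrogen, stayed within the scatter, so no step beyond the scatter is expected in this assay in either direction. Compound 3 is therefore expected to give 10000 nM, in a range from 4000 nM to 25000 nM, an expected step of a 1.1-fold lower number from compound 2 to compound 3 (0.05 log units; within the scatter).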

Compound 3, half-maximal inhibitory concentration: 11100 nM
The estimate for compound 3 lay 1.1-fold (0.05 log units) below the measured number, and the stated range covers the measured number.
By their numbers in this assay, from the lowest: compounds 1, 2 and 3 (each within the scatter of the next).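

In this assay, 3-methoxyphenyl in place of 2,5-dimethylphenyl on the amide-type nitrogen gives no change at the digits printed from compound 2 to compound 3 (within the scatter) and methoxy in place of hydrogen on an aromatic carbon gives a 1.2-fold higher number from compound 1 to compound 3 (0.09 log units; within the scatter). The entering group is thus the first here with a hydrogen-bond acceptor, and it still leaves all three compounds within the scatter of one another. No evidence is available to explain this result. On these data alone, whether an amine or a carboxylic acid on the phenyl ring, or a longer chain in its place, would give a step beyond the scatter remains open.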